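Replacing a Two-Ring Group with a Single Chlorinated Ring

This account rests on a few compounds, and the source may have more. Where it says the series, first, only, none or still open, it means among the compounds named here.

Compound 1, `O=C1C=CC2(C=C1)OCC(=O)N2c1nc(-c2ccc(F)c3ccccc23)nn1-c1ccccc1`: 200 nM
Compound 2, `CC1OC2(C=CC(=O)C=C2)N(c2nc(-c3ccc4ccccc4c3)nn2-c2ccccc2)C1=O`: 120 nM

Among the measured compounds shown here, in a functional assay on HeLa cells (Homo sapiens) for antiproliferative activity, with a stated time of 5 days (on this read-out lower numbers stand for stronger inhibition and higher numbers for weaker inhibition), compound 1 gives 200 nM, the higher of the two numbers measured so far. Compound 2 gives 120 nM in this assay, and the two values sit within the usual scatter of each other, so they count as the same for practical purposes.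

Compound 3, `O=C1C=CC2(C=C1)OCC(=O)N2c1nc(-c2cccc(Cl)c2)nn1-c1ccccc1`, has not yet been measured. It differs from compound 1 in one place: 3-chlorophenyl in place of 4-fluoronaphthalen-1-yl on an aromatic carbon. For the measured compounds named here, no measured pair of compounds shows what such a change does here, so the expectation rests on the structures alone. Compound 3 is expected to give a somewhat higher number than compound 1, meaning weaker inhibition. The step expected for compound 3 is a 2.5-fold higher number from compound 1 to compound 3 (0.40 log units; beyond the scatter), probably reaching beyond the scatter, though with real uncertainty. Compound 3 is therefore estimated at 500 nM, with a range from 150 nM to 2000 nM.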

Compound 3, half-maximal inhibitory concentration: 45.3 nM
Compound 3: middle estimate off by 11-fold (1.04 log units), on the high side, and the stated range ends above it.
By their numbers in this assay, from the lowest: compound 3; then compounds 2 and 1 (each within the scatter of the next).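

In this assay, the aromatic carbon of the five-membered ring does not need a two-ring group for a low number: 3-chlorophenyl in place of 4-fluoronaphthalen-1-yl gives a 4.4-fold lower number from compound 1 to compound 3 (0.64 log units; beyond the scatter). Among the compounds shown here, this is the first step read at this position, and it shows that a smaller group with one ring can do better here than the larger group with two. Nothing at hand gives a reason for this change.

The compounds shown do not separate the loss of the second ring from the arrival of the chlorine, nor do they show whether the place of the chlorine on the ring matters. A plain phenyl, a 4-chlorophenyl or a 3-methoxyphenyl group on the same carbon would speak to these questions.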